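The compounds below may be only part of what the source reports. "The series", "measured", "known", "first", "only" and "open" are said of these compounds alone.

Compound 1 `COc1c(/C=C2/C(=O)Nc3ccc(Cl)cc32)c2ccccc2n1-c1ccccc1` gives 5620 nM in a functional assay on cells (Melanoma cell, Homo sapiens) for cytotoxicity, with a stated time of 48 h; a lower number here means a stronger inhibitor of growth, a higher number a weaker inhibitor of growth.
Compound 2 `COc1cc2c(/C=C3/C(=O)Nc4ccc(Cl)cc43)c(Cl)n(Cc3cc(OC)c(OC)c(OC)c3)c2cc1C` gives 2290 nM.
Compound 3 `COc1cc2c(/C=C3/C(=O)Nc4cccc(Cl)c43)c(Cl)n(Cc3cc(OC)c(OC)c(OC)c3)c2cc1C` gives 2880 nM.

Compound 1 has the highest number of the three in this assay; its gap to compound 3 lies within the scatter, while its gap to compound 2 lies beyond it. Among the measured compounds shown here, the only single-site step among the measured compounds is a 1.3-fold higher number from compound 2 to compound 3 (0.10 log units; within the scatter), which moves the chloro from one aromatic carbon of the shared core to another without changing the count of atoms.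

Compound 4 `COc1c(/C=C2/C(=O)Nc3ccccc32)c2ccccc2n1-c1ccccc1` differs from compound 1 by hydrogen in place of chloro on an aromatic carbon. For the measured compounds named here, no measured pair bears directly on this change: the step from compound 2 to compound 3 keeps the chloro and only relocates it, and it stayed within the scatter. Taking that as the nearest guide, the loss of the chloro is expected to bring at most a modest step, a 1.4-fold higher number from compound 1 to compound 4 (0.15 log units; within the scatter), if anything toward a higher number. Compound 4 is therefore estimated at 8000 nM, with a range from 2500 nM to 25000 nM.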

Compound 4, concentration for 50% growth inhibition: 1480 nM
Estimate against measurement, compound 4: 5.4-fold (0.73 log units) above, and the stated range ends above it.
By their numbers in this assay, from the lowest: compounds 4, 2, 3 and 1 (each within the scatter of the next, the first and the last beyond it).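

Hydrogen in place of chloro gives a 3.8-fold lower number from compound 1 to compound 4 (0.58 log units; beyond the scatter) in this assay, so the chloro on this aromatic carbon of compound 1 does not simply go unnoticed: the compound without it has the lower number. The earlier step, a 1.3-fold higher number from compound 2 to compound 3 (0.10 log units; within the scatter), only moved the chloro within a differently substituted compound and stayed within the scatter, so it could not show what removing the group does. Nothing available explains why the removal lowers the number.

The compounds shown leave open whether removing the chloro from compound 2 or compound 3 would bring a similar step, since no hydrogen counterpart of either stands here. They also leave open how this carbon would respond to a fluoro, an amine or a carboxylic acid in place of the hydrogen of compound 4.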